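Fluoro in Place of Trifluoromethyl on an Aromatic Ring

This account rests on a few compounds, and the source may have more. Where it says the series, first, only, none or still open, it means among the compounds named here.

In a functional assay on A549 cells (Homo sapiens) for inhibition, read by MTT assay, with a stated time of 72 h (a higher number here means a weaker inhibitor, a lower number a stronger inhibitor), compound 1 `COc1ccccc1-c1csc2cnc(Nc3cc(F)c(C(=O)NC4CCNCC4)cc3F)nc12` gives 5390 nM and compound 2 `COc1ccccc1-c1csc2cnc(Nc3ccc(C(=O)NC4CCNCC4)cc3C(F)(F)F)nc12` gives 4110 nM on a shared core. These two numbers lie within the scatter of each other, so compound 2 stands level with compound 1. Compound 3 `COc1ccccc1-c1csc2cnc(Nc3ccc(C(=O)NC4CCNCC4)cc3F)nc12` differs from compound 2 by a single swap fluoro in place of trifluoromethyl on an aromatic carbon with fluoro in place of trifluoromethyl on an aromatic carbon, ortho to a large group and meta to a (piperidin-4-yl)carbamoyl group. Within the data shown here, no measured pair shows this change alone, so the evidence is thin. Compound 1 also carries fluoro on that ring and sits at 5390 nM in this assay without leaving the scatter of compound 2, so no step beyond the scatter is expected. The estimated step of a 1.1-fold higher number from compound 2 to compound 3 (0.04 log units; within the scatter) is expected to stay within the scatter, with no firm direction. The expected value for compound 3 is 4500 nM with a range of 1900 nM to 10000 nM as an estimate.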

Compound 3, half-maximal inhibitory concentration: 2750 nM
Beside the measured number, compound 3's estimate is 1.6-fold (0.21 log units) above it; measured number inside the range.
By their numbers in this assay, from the lowest: compounds 3, 2 and 1 (each within the scatter of the next).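

In this assay, among these compounds, fluoro in place of trifluoromethyl on this aromatic carbon gives a 1.5-fold lower number from compound 2 to compound 3 (0.17 log units; within the scatter), the first direct reading of this swap, and it shows that the single fluorine atom can stand in for the four heavy atoms of trifluoromethyl without a step beyond the scatter. Hydrogen in place of fluoro on an aromatic carbon gives a 2.0-fold lower number from compound 1 to compound 3 (0.29 log units; within the scatter), so this second single change on the same ring also stays within the scatter. No measurement at hand accounts for either step.

The compounds shown leave open how this aromatic carbon responds to a group of another kind, such as a nitrile or an amine. As far as these compounds go, whether any group here can move the number beyond the scatter also remains open.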